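Fluoro for chloro: a small step expected

The source may hold more compounds than are shown below. What is called first, only, known or untested is meant among the compounds shown, and "the series" means these compounds.

In a functional assay on HO8910 cells (Homo sapiens) for inhibition, read by MTT assay, with a stated time of 24 h, tested at 0.1 ug/mL (a higher number here means more inhibition of growth at the concentration tested, a lower number less inhibition of growth), compound 1 `O=C(CCCCC(S)CCS)Nc1ccccc1` gives 7.37%, compound 2 `O=C(CCCCC(S)CCS)Nc1ccccc1Cl` gives 6.11% and compound 3 `O=C(CCCCC(S)CCS)Nc1ccc(Cl)cc1` gives 1.04%. All three values lie within the scatter of one another, so compound 3 stands level with the other two on these numbers.

Compound 4 `O=C(CCCCC(S)CCS)Nc1ccc(F)cc1` differs from compound 3 in a single place, with fluoro in place of chloro on an aromatic carbon. Among the compounds with values here, no measured step makes exactly this swap. The closest evidence comes from the two steps that put chloro in place of hydrogen on an aromatic carbon, which are a number 1.3 percentage points lower from compound 1 to compound 2 (within the scatter) and a number 6.3 percentage points lower from compound 1 to compound 3 (within the scatter). Neither step leaves the scatter, so no clear change is expected from exchanging chloro for fluoro. The expected move is a number 3 percentage points higher from compound 3 to compound 4 (within the scatter), which is no real shift beyond the scatter. For compound 4 the estimated value in this assay is 4%, with an expected range from -3% to 12%.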

Compound 4, percent growth inhibition at one concentration: 8.11%
Compound 4: middle estimate off by 4.1 percentage points, on the low side; the range from low to high includes it.
By their numbers in this assay, from the lowest: compounds 3, 2, 1 and 4 (each within the scatter of the next).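

At this position, on an aromatic carbon para to a large group, the direct exchange of chloro for fluoro gives a number 7.1 percentage points higher from compound 3 to compound 4 (within the scatter) in this assay, so the two halogens cannot be told apart here. Fluoro in place of hydrogen gives a number 0.7 percentage points higher from compound 1 to compound 4 (within the scatter), which means that fluoro, like chloro in the earlier steps, does not separate from the unsubstituted compound 1 in this read-out. Nothing available offers an explanation for these readings.

The compounds shown leave open whether a different kind of group at this position, such as a methoxy group, an amine or a carboxylic acid, would produce a step beyond the scatter. They also leave open how changes to the two thiol groups on the chain would register in this test.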